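Removing a methoxy from compound 3

The source may report more compounds than this note shows. Statements on the series, on what has been measured and on what is new or still open speak of the compounds shown alone.

- compound 1 `Brc1ccc2[nH]cc(C(c3ccccc3)c3c[nH]c4ccc(Br)cc34)c2c1` gives 900 nM here
- compound 2 `COc1ccc(C(c2c[nH]c3ccc(Br)cc23)c2c[nH]c3ccc(Br)cc23)cc1` gives 5500 nM here
- compound 3 `COc1ccc(C(c2c[nH]c3ccc(Br)cc23)c2c[nH]c3ccc(Br)cc23)c(OC)c1` gives 63200 nM here

In a functional assay on HeLa cells (Homo sapiens) for inhibition, read by MTT assay, with a stated time of 48 h (a lower number here means a stronger inhibitor, a higher number a weaker inhibitor), compound 3 is the weakest of the three at 63200 nM on this scale. Compound 4 `CN(C)c1ccc(C(c2c[nH]c3ccc(Br)cc23)c2c[nH]c3ccc(Br)cc23)cc1` has 4-(dimethylamino)phenyl in place of 2,4-dimethoxyphenyl on a saturated chain carbon bound to two aromatic carbons with the rest unchanged. Going by the values given here, two measured steps bear on this: the large 11-fold higher number from compound 2 to compound 3 (1.06 log units; beyond the scatter) for a second methoxy, and the modest 6.1-fold higher number from compound 1 to compound 2 (0.79 log units; beyond the scatter) for the first. Among the compounds with values here, compound 4, like compound 2, carries a single group on that ring, though a different one, and no measurement yet compares the two groups. A large step toward a lower number is therefore expected (a 9.0-fold lower number from compound 3 to compound 4 (0.96 log units; beyond the scatter)). The estimated value for compound 4 is 7000 nM (range 1500 nM to 30000 nM).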

Compound 4, half-maximal inhibitory concentration: 12800 nM
Compound 4: middle estimate off by 1.8-fold (0.26 log units), on the low side; the measured number falls inside the stated range.
By their numbers in this assay, from the lowest: compound 1; then compound 2; then compound 4; then compound 3.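

In this assay, 4-(dimethylamino)phenyl recovers only part of what the 2,4-dimethoxyphenyl loses (a 4.9-fold lower number from compound 3 to compound 4 (0.69 log units; beyond the scatter)). Going by these compounds alone, it also gives the first direct comparison of two single groups on this ring, with dimethylamino in place of methoxy (a 2.3-fold higher number from compound 2 to compound 4 (0.37 log units; beyond the scatter)), while the plain phenyl stays ahead (a 14-fold higher number from compound 1 to compound 4 (1.15 log units; beyond the scatter)). No measurement here explains why these groups differ. Going by these compounds, whether any group on this ring can match hydrogen stays open, and a fluorine or a hydroxyl in the same place would test that.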